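Swapping the silyl group for azido in compound 3

The compounds below may be only part of what the source reports. "The series", "measured", "known", "first", "only" and "open" are said of these compounds alone.

Compound 1 `CC(C)=CCC[C@]1(C)/C=C/[C@@H](OC(=O)C=C(C)C)[C@](C)(O)/C=C/C(=O)/C(CCl)=C\C1` – 160 nM
Compound 2 `CC[Si](CC)(CC)C/C1=C/C[C@](C)(CCC=C(C)C)/C=C/[C@@H](OC(=O)C=C(C)C)[C@](C)(O)/C=C/C1=O` – 2810 nM

Going by the values given here, in a functional assay on HL-60 cells (Homo sapiens) for antiproliferative activity, read by MTT assay, with a stated time of 48 h (on this read-out higher numbers stand for weaker inhibition and lower numbers for stronger inhibition), compound 2 gives 2810 nM as the higher of the two numbers so far. Compound 3 `CC(C)=CCC[C@]1(C)/C=C/[C@@H](OC(=O)C=C(C)C)[C@](C)(O)/C=C/C(=O)/C(CN=[N+]=[N-])=C\C1` differs from it at one place: a group of 3 heavy atoms (3 nitrogen; no ring) in place of a group of 7 heavy atoms (6 carbon, 1 silicon; no ring), on a saturated chain carbon bound to a double-bonded ring carbon. Among the compounds with values here, one measured step bears on this, large and beyond the scatter: an 18-fold higher number from compound 1 to compound 2 (1.24 log units; beyond the scatter). Within the data shown here, that step brought in the same group that leaves here, with chlorine leaving, and no measurement yet compares chlorine with azido. The step expected in this assay therefore runs toward lower numbers, and is estimated, somewhat smaller than the measured one, as a 6.2-fold lower number from compound 2 to compound 3 (0.80 log units; beyond the scatter) in size. For compound 3 the estimated value is 450 nM with an expected range of 130 nM to 1600 nM overall.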

Compound 3, half-maximal inhibitory concentration: 910 nM
Beside the measured number, compound 3's estimate is 2.0-fold (0.31 log units) below it, and the stated range covers the measured number.
By their numbers in this assay, from the lowest: compound 1; then compound 3; then compound 2.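

In this assay, azido on this saturated chain carbon recovers only part of what the silicon-bearing group gave up, with a 3.1-fold lower number from compound 2 to compound 3 (0.49 log units; beyond the scatter), and it does not match chloro, with a 5.7-fold higher number from compound 1 to compound 3 (0.75 log units; beyond the scatter). Both steps lie beyond the scatter, so the three groups at this place fall in a clear order: chloro, then azido, then the silicon-bearing group. Nothing measured here accounts for that order.

On these data alone, whether an amine or a hydroxyl at this carbon would come closer to chloro stays open, as does whether the same order would hold in other cell lines.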